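Shortening a side chain on a shared purine-like core

The source may hold more compounds than are shown below. What is called first, only, known or untested is meant among the compounds shown, and "the series" means these compounds.

Compound 1 `CCCCCOc1nc(N)nc2c1ncn2/C=C1/CC1(CO)CO` is measured in an ADME assay on MOLT-3 cells (Homo sapiens) for cytotoxicity, with a stated time of 7 days (a higher number here means that more compound is tolerated, a lower number that less compound is tolerated), and gives only the limit > 20000 nM. Compound 2 `CCCCNc1nc(N)nc2c1ncn2/C=C1/CC1(CO)CO` gives only the limit > 20000 nM in this assay. Compound 3 `CCCCCCCCSc1nc(N)nc2c1ncn2/C=C1/CC1(CO)CO` likewise gives only the limit > 20000 nM in this assay.

Compound 3 therefore stands where every measured compound stands: at the limit of > 20000 nM in this assay, at which 3 of the 3 values shown sit, a limit rather than a number. Compound 4 `CNc1nc(N)nc2c1ncn2/C=C1/CC1(CO)CO` differs from compound 3 in one place: methylamino in place of octylsulfanyl on an aromatic carbon. The measured steps that touch the same position are a step that the two limits leave unreadable from compound 2 to compound 3, a step that the two limits leave unreadable from compound 1 to compound 3 and a step that the two limits leave unreadable from compound 1 to compound 2, and none of them can be read, since both ends of each step are limits. They show only that swapping pentyloxy, butylamino and octylsulfanyl at this carbon kept every compound at the limit. The change to methylamino is expected to behave the same way, so the expected step is a number no higher from compound 3 to compound 4 (the limit leaves the size open), none beyond the scatter. Compound 4 is estimated at 20000 nM, between 7000 nM and 60000 nM, most likely again reported as a limit.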

Compound 4, half-maximal cytotoxic concentration: > 20000 nM
Compound 4: a limit, no number (the forecaster's own chance of this, stated with the estimate: 70%); the middle value sits exactly at the limit.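

Compound 4 also gives only a limit, so its steps from compound 1, compound 2 and compound 3 in this assay cannot be read, as both ends of each step are limits: the limit of > 20000 nM in this assay, at which 4 of the 4 values shown sit. The compounds shown leave open at what concentration any of them turns cytotoxic, and whether changing the group on this carbon shifts that concentration.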